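Bromo for chloro: the step from compound 3 to compound 4

The compounds below may be only part of what the source reports. "The series", "measured", "known", "first", "only" and "open" are said of these compounds alone.

Compound 3 `Fc1ccc(C2=NN(c3ccccc3)C(c3cn(-c4ccccc4)nc3-c3ccc(Cl)cc3)C2)cc1` gives 43% in a functional assay on the whole organism (Tail) with Rattus norvegicus as the target, in the tail flick test, with a stated time of 60 min, at a dose of 25 mg/kg by the oral route; on this read-out lower numbers stand for less inhibition and higher numbers for more inhibition at the one dose given (going by the name of the read-out). Among the three numbers known so far compound 3 stands second highest; its nearest neighbour is compound 2 `Fc1ccc(C2=NN(c3ccccc3)C(c3cn(-c4ccccc4)nc3-c3ccc(F)cc3)C2)cc1`, which gives 41%, a difference within the scatter, and the furthest is compound 1 `CC(=O)N1N=C(c2ccc(F)cc2)CC1c1cn(-c2ccccc2)nc1-c1ccc(Br)cc1`, which gives 71%, a difference beyond the scatter. Compound 4 `Fc1ccc(C2=NN(c3ccccc3)C(c3cn(-c4ccccc4)nc3-c3ccc(Br)cc3)C2)cc1` awaits measurement. The change is bromo in place of chloro on an aromatic carbon.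

Among the compounds with values here, the one measured step on the same core that bears on this change is a number 2 percentage points higher from compound 2 to compound 3 (within the scatter), a halogen exchange at the same position that left the read-out essentially unchanged. Within the data shown here, compound 1 carries the bromo group too, but it differs from compound 3 in a second place as well, so no single-change step connects them and its number speaks only for itself.

On that basis compound 4 is expected to sit close to compound 3, with an estimated step of a number 2 percentage points higher from compound 3 to compound 4 (within the scatter), not beyond the scatter. The estimate for compound 4 is 45%, expected between 32% and 58%.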

Compound 4, a percentage reported as inhibition, in the whole organism at one dose (the size of the read-out at that dose, not a potency): 71%
Beside the measured number, compound 4's estimate is 26 percentage points below it, and the stated range ends below it.
By their numbers in this assay, from the lowest: compounds 2 and 3 (each within the scatter of the next); then compounds 1 and 4 (each within the scatter of the next).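

In the shared core the halogen on this aromatic carbon is not interchangeable: the change from chloro to bromo gives a number 28 percentage points higher from compound 3 to compound 4 (beyond the scatter) in this assay, and the change from fluoro to bromo gives a number 30 percentage points higher from compound 2 to compound 4 (beyond the scatter), while the change from fluoro to chloro gave only a number 2 percentage points higher from compound 2 to compound 3 (within the scatter). Within the data shown here, with the 4-bromophenyl group held constant, the substituent on the ring amine nitrogen can also be compared for the first time, and phenyl in place of acetyl gives no change at the digits printed from compound 1 to compound 4 (within the scatter). No measurement at hand accounts for the separation of bromo from chloro and fluoro.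

On these data alone, whether this higher level extends to iodo, methyl, methoxy or trifluoromethyl at the same aromatic carbon remains open. Also open, as far as these compounds go, is whether acetyl and phenyl on the ring amine nitrogen stay level when chloro or fluoro replaces bromo.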